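A Larger Group on the Carbonyl Carbon

A few compounds are considered here, and "the series" means these few. Any claim that something is new, unique, unknown or untested is made for them only; others in the source may bear on it.

Three measured compounds, each with its number in the same test:
compound 1, `Cc1c(OCCCCOc2ccccc2C(=O)O)ccc(C(=O)CC2CCCC2)c1O`: 335 nM
compound 2, `CCCC(=O)c1ccc(OCCCCOc2cc(C(=O)O)ccc2OC)c(C)c1O`: 103 nM
compound 3, `CC(=O)c1ccc(OCCCCOc2cccc(C(=O)O)c2C)c(C)c1O`: 200 nM

All three were measured in an assay on HEK293 cells for positive allosteric modulation of metabotropic glutamate receptor 2 (Rattus norvegicus), read by thallium flux, with a stated time of 2.5 min; a higher number here means that more compound is needed for the effect, a lower number that less compound is needed. On the bare numbers, compound 3 stands second highest of the three, yet its gap to compound 1 and its gap to compound 2 both lie within the scatter of this assay, so none of the three can be called more or less potent than another.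

Compound 4, `Cc1c(OCCCCOc2ccc(C(=O)C(C)C)c(O)c2C)cccc1C(=O)O`, has not yet been measured. It differs from compound 3 in one place: isopropyl in place of methyl on a carbonyl carbon. Seen one bond further out, acetyl becomes isopropylcarbonyl. Among the compounds with values here, no pair of measured compounds differs in a single place, so there is no measured step to lean on; the two other compounds, which differ from compound 3 in more than one place, merely show numbers within its scatter.

The step from compound 3 to compound 4 in this assay is expected to be small, a 1.3-fold lower number from compound 3 to compound 4 (0.12 log units; within the scatter), leaning slightly toward a lower number but not clearly beyond the scatter. Compound 4 is therefore estimated at 150 nM, with a likely range from 60 nM to 400 nM.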

Compound 4, half-maximal effective concentration: 149 nM
Estimate against measurement, compound 4: 1.0-fold (0.00 log units) above, within the range that was stated.
By their numbers in this assay, from the lowest: compounds 2, 4, 3 and 1 (each within the scatter of the next, the first and the last beyond it).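

Within the data shown here, replacing methyl with isopropyl on a carbonyl carbon gives the first comparison here in which only one place changes, and in this assay the step of a 1.3-fold lower number from compound 3 to compound 4 (0.13 log units; within the scatter) does not separate the two compounds. At this position, then, the group can grow from 1 heavy atom to 3 heavy atoms, all carbon, with no clear change in the amount of compound needed for the effect, something that compound 1 and compound 2 could not show, as each differs from compound 3 in more than one place. Nothing available explains why this change leaves the number within the scatter.

Still open, on these data alone, is how far this tolerance extends: tert-butyl or phenyl on the same carbonyl carbon, or a chain ending in an amine, might keep the number in this range or might move it clearly. It is also unknown whether the same swap would give so small a step on the differently substituted acid-bearing rings of compound 1 and compound 2, since a single step on one pair cannot establish a general rule.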